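Methylating the free hydroxy of compound 1

A few compounds are considered here, and "the series" means these few. Any claim that something is new, unique, unknown or untested is made for them only; others in the source may bear on it.

- compound 1 `O=C(/C=C/c1ccc(OCCCCCO[N+](=O)[O-])c(O)c1)OCCCCCO[N+](=O)[O-]` gives 2710 nM in the assay below
- compound 2 `COc1cc(/C=C/C(=O)OC(C)CCOc2no[n+]([O-])c2S(=O)(=O)c2ccccc2)ccc1O` gives 400 nM in the assay below
- compound 3 `COc1cc(/C=C/C(=O)Oc2cccc(OCc3c(-c4ccccc4)no[n+]3[O-])c2)ccc1O` gives 14200 nM in the assay below

All three values come from a functional assay on SKBR cells (Homo sapiens) for cytotoxicity, read by resazurin assay, with a stated time of 72 h (a lower number here means a stronger inhibitor, a higher number a weaker inhibitor), and span a wide range. Compound 1 holds the second highest of the three numbers. It sits beyond the scatter from both neighbours, with compound 3 (14200 nM) higher and compound 2 (400 nM) lower.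

The next compound to be tested is compound 4 `COc1cc(/C=C/C(=O)OCCCCCO[N+](=O)[O-])ccc1OCCCCCO[N+](=O)[O-]`. It differs from compound 1 at one place: methyl in place of hydrogen on an oxygen on an aromatic ring. Put simply, hydroxy becomes methoxy.

Among the measured compounds shown here, no two measured compounds differ in only one place, so the size of this change in this assay has not been observed. Compound 2 (400 nM) and compound 3 (14200 nM) both carry a methoxy group yet lie far apart, so they give no direction for the change. The working expectation is therefore no step beyond the scatter, with a wide margin on either side.

The estimated step is a 1.1-fold lower number from compound 1 to compound 4 (0.04 log units; within the scatter) in this assay and is expected to stay within the scatter. For compound 4 the expected value is 2500 nM with an estimated range of 800 nM to 8000 nM in this series.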

Compound 4, half-maximal inhibitory concentration: > 50000 nM
Compound 4 was reported as a limit; the forecaster's own chance of this, stated with the estimate: 5%; middle value at least 20-fold (1.30 log units) from the limit.
By their numbers in this assay, from the lowest: compound 2; then compound 1; then compound 3. At a limit, above all of these: compound 4.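

In this assay, compound 4 is reported only as a limit of the assay, not as a number: the limit of > 50000 nM in this assay, at which 1 of the 4 values shown sits.

The pair gives the series its first one-place comparison, and the step reads an at least 18-fold higher number from compound 1 to compound 4 (1.26 log units; beyond the scatter), so hydroxy to methoxy at this oxygen on an aromatic ring is not a neutral change for compound 1. Compound 2 and compound 3 also carry a methoxy group but differ from compound 1 in more than one place, so they could not show that this single methyl in place of hydrogen is enough to move the result this far.

The compounds shown do not separate the loss of the hydrogen from the arrival of the methyl, and an amine in place of the hydroxy, or an ethyl group on the same oxygen, would bear on that question. From the compounds shown here alone, this is also a single pair, so whether the same change has a comparable effect in the settings of compound 2 or compound 3, with their different ester groups, remains open.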